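Chlorine placement on the phenyl group: compound 3 to compound 4

This account rests on a few compounds, and the source may have more. Where it says the series, first, only, none or still open, it means among the compounds named here.

- compound 1 `Cc1ccsc1-c1cc(-c2ccc(Cl)o2)cc(-c2ccc(Cl)cc2)n1`: 15300 nM
- compound 2 `Cc1ccc(-c2cc(-c3ccc(Cl)o3)cc(-c3ccc(Cl)s3)n2)cc1`: 3040 nM
- compound 3 `Clc1cccc(-c2cc(-c3ccc(Cl)o3)cc(-c3ccc(Cl)s3)n2)c1`: 15100 nM

All three values come from a functional assay on MCF7 cells (Homo sapiens) for cytotoxicity, read by ELISA, with a stated time of 4 days; a lower number here means a stronger inhibitor, a higher number a weaker inhibitor. Compound 3 lies within the scatter of compound 1, while compound 2 stands beyond the scatter on the lower side.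

The next compound is compound 4 `Clc1ccc(-c2cc(-c3ccc(Cl)o3)cc(-c3ccc(Cl)s3)n2)cc1`, which has the same atoms as compound 3, joined differently: 4-chlorophenyl in place of 3-chlorophenyl on an aromatic carbon. The group moves to 4-chlorophenyl from 3-chlorophenyl, on the aromatic carbon next to the ring nitrogen.

Within the data shown here, one measured step bears directly on this place, a 5.0-fold higher number from compound 2 to compound 3 (0.70 log units; beyond the scatter). That modest step replaces 4-methylphenyl with 3-chlorophenyl, so it changes both the substituent and its position, and the data do not separate the two. Compound 4 keeps the chlorine of compound 3 but shares the 4-substitution of compound 2. This points to a partial return towards the lower number. Compound 1 goes against that reading, since it also carries 4-chlorophenyl and gives 15300 nM, although it differs elsewhere in the structure.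

A modest step to a lower number is therefore expected, with little confidence in its size. The expected change is a 2.2-fold lower number from compound 3 to compound 4 (0.33 log units; beyond the scatter). For compound 4 the estimated value is 7000 nM, with an expected range from 2500 nM to 18000 nM.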

Compound 4, half-maximal inhibitory concentration: 12600 nM
Estimate against measurement, compound 4: 1.8-fold (0.26 log units) below, within the range that was stated.
By their numbers in this assay, from the lowest: compound 2; then compounds 4, 3 and 1 (each within the scatter of the next).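

Moving the chlorine from 3-chlorophenyl to 4-chlorophenyl on this aromatic carbon gives a 1.2-fold lower number from compound 3 to compound 4 (0.08 log units; within the scatter), so this assay does not distinguish these two chlorophenyl groups. The step with a 4.1-fold higher number from compound 2 to compound 4 (0.62 log units; beyond the scatter) changes only methyl to chloro, which separates what the earlier comparison of 4-methylphenyl with 3-chlorophenyl left mixed: among compounds 2, 3 and 4, the step beyond the scatter follows the exchange of methyl for chloro, not the placement of the chlorine. Exchanging 3-methylthiophen-2-yl for 5-chlorothiophen-2-yl at the same kind of place, with 4-chlorophenyl on the other side of the core, gives a 1.2-fold lower number from compound 1 to compound 4 (0.08 log units; within the scatter), so that change also stays within the scatter.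

Nothing measured here explains why methyl and chloro on the phenyl group part in this way. Among these compounds, compound 2 is the only compound with a methyl on that phenyl group, so it remains open whether the lower number is specific to methyl or would also appear with a methoxy group or an amine in its place.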